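Replacing isobutylamino with piperazin-1-yl on a carbonyl carbon

The source may hold more compounds than are shown below. What is called first, only, known or untested is meant among the compounds shown, and "the series" means these compounds.

Measured in a functional assay on A549 cells (Homo sapiens) for inhibition, read by sulforhodamine B assay, with a stated time of 72 h; a lower number here means a stronger inhibitor, a higher number a weaker inhibitor:
- compound 1 `Nc1sc(-c2ccc(Cl)cc2)c(-c2ccc(Cl)cc2)c1C(=O)N1CCCCC1=O`: 1820 nM
- compound 2 `Nc1sc(-c2ccc(Cl)cc2)c(-c2ccc(Cl)cc2)c1C(=O)N1CCOCC1`: 1870 nM
- compound 3 `CC(C)CNC(=O)c1c(N)sc(-c2ccc(Cl)cc2)c1-c1ccc(Cl)cc1`: 21000 nM

Compound 3 has the highest number of the three, so it is the weakest inhibitor here. The next compound, compound 4 `Nc1sc(-c2ccc(Cl)cc2)c(-c2ccc(Cl)cc2)c1C(=O)N1CCNCC1`, differs from it by one change: piperazin-1-yl in place of isobutylamino on a carbonyl carbon. In words, piperazin-1-yl takes the place of isobutylamino on a carbonyl carbon.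

Within the data shown here, two measured steps bear most directly on this change: a 12-fold higher number from compound 1 to compound 3 (1.06 log units; beyond the scatter) and an 11-fold higher number from compound 2 to compound 3 (1.05 log units; beyond the scatter). Both are large, and both lead to compound 3 from a compound with a ring group in that place. Swapping one ring group for the other gave a 1.0-fold higher number from compound 1 to compound 2 (0.01 log units; within the scatter), which suggests that the exact ring may matter little. Among the measured compounds shown here, no piperazin-1-yl compound has been measured yet, however, so this remains an extrapolation. A large step to a lower number is therefore expected in this assay, perhaps slightly smaller than those two. The expected step is an 8.4-fold lower number from compound 3 to compound 4 (0.92 log units; beyond the scatter). Compound 4 is estimated at 2500 nM, with an expected range of 900 nM to 8000 nM.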

Compound 4, half-maximal inhibitory concentration: 1020 nM
Estimate against measurement, compound 4: 2.5-fold (0.39 log units) above; the range from low to high includes it.
By their numbers in this assay, from the lowest: compounds 4, 1 and 2 (each within the scatter of the next); then compound 3.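

In this assay, a third ring group now stands well apart from the open-chain isobutylamino group on the carbonyl carbon, with a 21-fold lower number from compound 3 to compound 4 (1.31 log units; beyond the scatter); among the four compounds, compound 3 alone lies beyond the scatter of the others. Within the ring groups, the steps remain small: a 1.8-fold lower number from compound 2 to compound 4 (0.26 log units; within the scatter) and a 1.8-fold lower number from compound 1 to compound 4 (0.25 log units; within the scatter), so piperazin-1-yl cannot be told apart from morpholin-4-yl or 2-oxopiperidin-1-yl. No measurement is available to explain why the ring compounds differ from compound 3.

Compound 3 differs from the ring compounds in two ways, as it has both an open chain and the amide hydrogen, and these compounds cannot separate the two. A diethylamino group would keep an open chain without that hydrogen, while a pyrrolidin-1-yl group would test a smaller ring.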